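The source may hold more compounds than are shown below. What is called first, only, known or untested is meant among the compounds shown, and "the series" means these compounds.

Among the compounds with values here, compound 3 `CCOCNc1n[n+]([O-])c2ccccc2[n+]1[O-]` gives 7400 nM in a functional assay on PC-3 cells (Homo sapiens) for cytotoxicity, read by MTT assay, with a stated time of 72 h (a lower number here means a stronger inhibitor, a higher number a weaker inhibitor), the second highest of the three numbers measured so far. Compound 2 `CCCCOCNc1n[n+]([O-])c2ccccc2[n+]1[O-]` gives 6010 nM, and a 1.2-fold higher number from compound 2 to compound 3 (0.09 log units; within the scatter), a step within the scatter. Compound 1 `COc1ccc(COCNc2n[n+]([O-])c3ccccc3[n+]2[O-])cc1` gives 52800 nM, and a 7.1-fold lower number from compound 1 to compound 3 (0.85 log units; beyond the scatter). Compound 4 `CCCCCCCOCNc1n[n+]([O-])c2ccccc2[n+]1[O-]` has not been measured; it differs from compound 3 by pentyl in place of hydrogen on a saturated chain carbon, two bonds along the chain from an oxygen on a saturated carbon. Within the data shown here, the only measured step at that place, from compound 2 to compound 3, put hydrogen in place of ethyl and stayed within the scatter, so a longer chain there is expected to move the number little in this assay. The expected step is therefore a 1.3-fold lower number from compound 3 to compound 4 (0.13 log units; within the scatter), no more than the scatter. Compound 4 is accordingly estimated at 5500 nM, with a range from 1800 nM to 17000 nM.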

Compound 4, half-maximal inhibitory concentration: 390 nM
Estimate against measurement, compound 4: 14-fold (1.15 log units) above, outside the stated range (below it).
By their numbers in this assay, from the lowest: compound 4; then compounds 2 and 3 (each within the scatter of the next); then compound 1.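

In this assay the length of the chain at this place turns out not to be neutral: there is a 19-fold lower number from compound 3 to compound 4 (1.28 log units; beyond the scatter) with pentyl in place of hydrogen, and a 15-fold lower number from compound 2 to compound 4 (1.19 log units; beyond the scatter) with propyl in place of hydrogen, although compound 2 and compound 3 lie within the scatter of each other. Hexyl in place of 4-methoxyphenyl gives the largest step in the series, a 140-fold lower number from compound 1 to compound 4 (2.13 log units; beyond the scatter). Nothing measured here bears on what lies behind this drop. The compounds shown leave open whether a chain longer than that of compound 4 would lower the number further, and what a chain of intermediate length, a branched chain or an amine on the chain would give.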